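Aryl versus alkyl hydroxamate linkers on a shared core

The source may hold more compounds than are shown below. What is called first, only, known or untested is meant among the compounds shown, and "the series" means these compounds.

Of the compounds shown here, three sharing one core have been measured in a functional assay on MCF7 cells (Homo sapiens) for antiproliferative activity, read by CCK-8 assay, with a stated time of 72 h; a lower number here means a stronger inhibitor, a higher number a weaker inhibitor. Compound 1 `CCOc1cc(C(C)(C)C)ccc1C1=NC(c2ccc(Cl)cc2)C(c2ccc(Cl)cc2)N1C(=O)NCCCCCCCC(=O)NO` gives 7920 nM. Compound 3 `CCOc1cc(C(C)(C)C)ccc1C1=NC(c2ccc(Cl)cc2)C(c2ccc(Cl)cc2)N1C(=O)N1CCN(CCCCCCCC(=O)NO)CC1` gives 4830 nM, and compound 2 `CCOc1cc(C(C)(C)C)ccc1C1=NC(c2ccc(Cl)cc2)C(c2ccc(Cl)cc2)N1C(=O)N1CCN(Cc2ccc(C(=O)NO)cc2)CC1` gives 3970 nM. The difference between the cores of compound 1 and compound 3 is not broken down here. Going from compound 3 to compound 2 means (4-(hydroxycarbamoyl)phenyl in place of 6-(hydroxycarbamoyl)hexyl on a saturated chain carbon bound to an amine nitrogen in a ring), a change that produced a 1.2-fold lower number from compound 3 to compound 2 (0.09 log units; within the scatter). Compound 4 `CCOc1cc(C(C)(C)C)ccc1C1=NC(c2ccc(Cl)cc2)C(c2ccc(Cl)cc2)N1C(=O)NCc1ccc(C(=O)NO)cc1` is not yet measured; relative to compound 1 it carries 4-(hydroxycarbamoyl)phenyl in place of 6-(hydroxycarbamoyl)hexyl on a saturated chain carbon bound to an amide-type nitrogen, the same kind of change, here on a saturated chain carbon bound to an amide-type nitrogen rather than to an amine nitrogen in a ring. Because the earlier step of a 1.2-fold lower number from compound 3 to compound 2 (0.09 log units; within the scatter) stayed within the scatter, compound 4 is expected to move by about a 1.3-fold lower number from compound 1 to compound 4 (0.10 log units; within the scatter). Compound 4 is therefore estimated at 6300 nM, between 2800 nM and 14000 nM.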

Compound 4, half-maximal inhibitory concentration: 13300 nM
The estimate for compound 4 lay 2.1-fold (0.32 log units) below the measured number; low and high end bracket the measured number.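

In this assay, 4-(hydroxycarbamoyl)phenyl in place of 6-(hydroxycarbamoyl)hexyl on a saturated chain carbon bound to an amide-type nitrogen gives a 1.7-fold higher number from compound 1 to compound 4 (0.23 log units; within the scatter). Set beside the earlier step, the two cores cannot be told apart: the same change on two cores in this assay, a 1.2-fold lower number (0.09 log units; within the scatter) from compound 3 to compound 2 and a 1.7-fold higher number (0.23 log units; within the scatter) from compound 1 to compound 4, 2.0-fold (0.31 log units) apart, within the scatter of two such steps. The change therefore carries from one core to the other without a step beyond the scatter on either, but two such pairs do not show that it has any real effect on this read-out, or that the core alters its outcome.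

The compounds shown leave open whether a shorter or longer chain bearing the hydroxycarbamoyl group would shift the number beyond the scatter. They also leave open what a carboxylic acid in place of that group would do.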